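Shrinking a Cyanoalkyl Chain to a Pyrrolidine Ring

The source may hold more compounds than are shown below. What is called first, only, known or untested is meant among the compounds shown, and "the series" means these compounds.

Compound 1 `CCn1nc(C(=O)N[C@H]2COc3ccccc3N(C)C2=S)nc1Cc1ccccc1`: 17 nM
Compound 2 `CCCCCn1nc(C(=O)N[C@H]2COc3ccccc3N(C)C2=S)nc1Cc1ccccc1`: 805 nM
Compound 3 `CN1C(=S)[C@@H](NC(=O)c2nc(Cc3ccccc3)n(CCCCCC#N)n2)COc2ccccc21`: 3830 nM

In a functional assay on HT-29 cells (Homo sapiens) for inhibition, read by luminescence and CellTiter-Glo, with a stated time of 24 h (a higher number here means that more compound is needed for the effect, a lower number that less compound is needed), compound 3 gives the highest number of the three, with compound 2 nearest and compound 1 furthest. Compound 4 `CN1C(=S)[C@@H](NC(=O)c2nc(Cc3ccccc3)n(C3CCNC3)n2)COc2ccccc21` differs from compound 3 in one place: pyrrolidin-3-yl in place of 5-cyanopentyl on an aromatic nitrogen. The measured steps all concern what hangs from that aromatic nitrogen. The step of a 47-fold higher number from compound 1 to compound 2 (1.68 log units; beyond the scatter) and the step of a 230-fold higher number from compound 1 to compound 3 (2.35 log units; beyond the scatter) show that lengthening the chain raised the number strongly, while a 4.8-fold higher number from compound 2 to compound 3 (0.68 log units; beyond the scatter) shows a modest rise from the nitrile. Among the measured compounds shown here, the pyrrolidin-3-yl group is shorter than 5-cyanopentyl and lacks the nitrile, so a lower number than compound 3 is expected, though the ring and its hydrogen-bond donor have no precedent here. Compound 4 is estimated at 400 nM, between 60 nM and 2500 nM, an expected step of a 9.6-fold lower number from compound 3 to compound 4 (0.98 log units; beyond the scatter).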

Compound 4, half-maximal effective concentration: 1070 nM
Beside the measured number, compound 4's estimate is 2.7-fold (0.43 log units) below it, within the range that was stated.
By their numbers in this assay, from the lowest: compound 1; then compounds 2 and 4 (each within the scatter of the next); then compound 3.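

In this assay, swapping the long nitrile chain for a ring on this nitrogen regains only a little, with a 3.6-fold lower number from compound 3 to compound 4 (0.55 log units; beyond the scatter). Pyrrolidin-3-yl and pentyl cannot be told apart, at a 1.3-fold higher number from compound 2 to compound 4 (0.12 log units; within the scatter), which lies within the scatter, and the ring remains far from ethyl, with a 63-fold higher number from compound 1 to compound 4 (1.80 log units; beyond the scatter), so tying the chain into a compact ring does not by itself return the number of compound 1. Nothing available here explains these steps.

Still open, from the compounds shown here alone, is whether an azetidine ring, or a methyl group on the pyrrolidine nitrogen, would bring the number closer to that of compound 1. A short chain ending in an amine is equally untested among the compounds shown.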